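A few compounds are considered here, and "the series" means these few. Any claim that something is new, unique, unknown or untested is made for them only; others in the source may bear on it.

Compound 3, `CCc1oc2cc(O)ccc2c1C(=O)c1ccc(OC)cc1`, is one of a set of four built on a shared core. Its relative compound 1, `CCc1oc2cc(OC)ccc2c1C(=O)c1ccc(OC)cc1`, has both oxygens on the aromatic rings carrying methyl, and compound 2, `CCc1oc2cc(OC)ccc2c1C(=O)c1ccc(O)cc1`, carries a hydroxy in place of the methoxy on the benzoyl ring. In an assay for inhibition of solute carrier family 22 member 12 (Homo sapiens), read by scintillation counting, with a stated time of 60 min (a lower number here means a stronger inhibitor, a higher number a weaker inhibitor), compound 2 gives 3920 nM, whereas for compound 1 the outcome is "not determined" (no result reported) and for compound 3 it is likewise "not determined" (no result reported), so compound 3 stands without a number of its own. Compound 4, `CCc1oc2cc(O)ccc2c1C(=O)c1ccc(O)cc1`, differs from compound 3 by hydrogen in place of methyl on an oxygen on an aromatic ring. With no measured step of this kind in this assay to lean on, a modest change within or slightly beyond the scatter is expected. Compound 4 is estimated at 2000 nM, with a range from 500 nM to 8000 nM.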

Compound 4, half-maximal inhibitory concentration: 1130 nM
Compound 4: middle estimate off by 1.8-fold (0.25 log units), on the high side; measured number inside the range.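

In this assay hydrogen in place of methyl on an oxygen on an aromatic ring now has a readable step, a 3.5-fold lower number from compound 2 to compound 4 (0.54 log units; beyond the scatter), at the oxygen on the shared core with the benzoyl hydroxy kept. This modest step shows that the change at this oxygen registers beyond the usual scatter, while the steps at the benzoyl oxygen cannot be read. No evidence on its cause is available. On these data alone, whether the benzoyl oxygen responds alike stays open. So does the effect of an amine or a carboxylic acid at either oxygen.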